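This account rests on a few compounds, and the source may have more. Where it says the series, first, only, none or still open, it means among the compounds named here.

Measured so far:
compound 1, `Brc1cccc2c1nnn2Cc1ccccc1`: 80 nM
compound 2, `Brc1cccc2c1nnn2CC1CCCCC1`: 10 nM
compound 3, `Brc1cccc2c1nnn2CC1CCC1`: 20 nM

Of the compounds shown here, three have been tested in a functional assay on cells for positive allosteric modulation of metabotropic glutamate receptor 2 (Homo sapiens), read by fluorescence and calcium flux, with a stated time of 30 min; on this read-out lower numbers stand for an effect already at smaller amounts and higher numbers for an effect only at larger amounts of compound. They share one core and differ only in the group carried on the saturated chain carbon bound to the aromatic nitrogen. Compound 3 stands second highest of the three numbers: its nearest neighbour is compound 2, whose number is lower by an amount that stays within the usual scatter, while compound 1 lies furthest off, with a number higher by an amount beyond the scatter. Compound 4 `CCCn1nnc2c(Br)cccc21` has not yet been measured. It differs from compound 3 by ethyl in place of cyclobutyl on a saturated chain carbon bound to an aromatic nitrogen. Among the measured compounds shown here, no pair of measured compounds shows this change, so the direction can only be judged from the three numbers at hand, where the two compounds bearing a saturated ring, compound 2 and compound 3, both give lower numbers than compound 1. Removing the ring altogether is therefore expected to move the number in this assay upward, by a modest step that reaches just beyond the scatter. Compound 4 is expected to give 50 nM, with a range from 15 nM to 160 nM. The estimate means a step of a 2.5-fold higher number from compound 3 to compound 4 (0.40 log units; beyond the scatter).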

Compound 4, half-maximal effective concentration: 270 nM
Estimate against measurement, compound 4: 5.4-fold (0.73 log units) below; measured number outside the range, above it.
By their numbers in this assay, from the lowest: compounds 2 and 3 (each within the scatter of the next); then compound 1; then compound 4.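

In this assay, among the compounds shown here, the change of ethyl in place of cyclobutyl on a saturated chain carbon bound to an aromatic nitrogen is a large one, a 14-fold higher number from compound 3 to compound 4 (1.13 log units; beyond the scatter), and it is the first view of this place without a ring, since the three earlier compounds all carry one there. With compound 4 at 270 nM and compound 1 at 80 nM, the open chain also gives a higher number than the compound with the aromatic ring, so among these four compounds the saturated rings of compound 2 and compound 3 stand lowest, the aromatic ring comes next and ethyl stands last. Nothing at hand accounts for the size of this step.

The compounds shown leave open whether the low numbers depend on the ring itself or on the size of the group, which a longer chain such as butyl, a branched chain such as isobutyl or a smaller ring such as cyclopropyl at this place would separate. They also leave open how this place tolerates a group carrying an amine or an ether oxygen, and whether the shared core behaves the same way with a chlorine in place of its bromine.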